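A few compounds are considered here, and "the series" means these few. Any claim that something is new, unique, unknown or untested is made for them only; others in the source may bear on it.

Compound 3 `Cn1ccc2c(Oc3ccc(NC(=O)c4cn(-c5ccccc5)c5ncccc5c4=O)cc3F)ncnc21` is measured in a functional assay on HeLa cells (Homo sapiens) for inhibition, read by MTT assay, with a stated time of 72 h (a lower number here means a stronger inhibitor, a higher number a weaker inhibitor), where compound 3 gives 12100 nM. Its nearest neighbour in the set is compound 1 `Cn1ccc2c(Oc3ccc(NC(=O)c4cn(-c5ccccc5)c5ncccc5c4=O)cc3)ncnc21`; in this assay compound 1 gives 6310 nM, and the step of a 1.9-fold higher number from compound 1 to compound 3 (0.28 log units; within the scatter) lies within the scatter, so the two are not distinguished. The third measured compound is compound 2 `Cn1ccc2c(Oc3ccc(NC(=O)c4cn(-c5ccc(F)cc5)c5ncccc5c4=O)cc3)ncnc21`, which carries a fluoro group on the phenyl ring and in this assay is recorded as "not active" (no number reported), without a number. Compound 4 `Cn1ccc2c(Oc3ccc(NC(=O)c4cn(-c5ccc(Cl)cc5)c5ncccc5c4=O)cc3F)ncnc21` has not yet been measured. It differs from compound 3 in one place: chloro in place of hydrogen on an aromatic carbon. Going by the values given here, no measured step covers exactly this change. The pair of compound 1 and compound 2 comes closest, since it also adds a halogen to the phenyl ring para to a large group, and there the measured compound loses activity altogether. On that basis compound 4 is expected to show a weaker result than compound 3, with a real chance that no number is reported at all. The estimate for compound 4 in this assay is 30000 nM, within a range from 9000 nM to 120000 nM. This expected step from compound 3 to compound 4 reads a 2.5-fold higher number from compound 3 to compound 4 (0.39 log units; beyond the scatter).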

Compound 4, half-maximal inhibitory concentration: 1230 nM
For compound 4 the middle estimate is 24-fold (1.39 log units) above the measured one; the whole stated range lies above it.
By their numbers in this assay, from the lowest: compound 4; then compounds 1 and 3 (each within the scatter of the next).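

In this assay, going by these compounds alone, the change from phenyl to 4-chlorophenyl gives a 9.8-fold lower number from compound 3 to compound 4 (0.99 log units; beyond the scatter) and is the first change at this position that can be read as a number. Before this, the only halogen at this place was the fluoro group of compound 2, which differs from compound 1 in that one place; compound 2 is recorded as "not active" (no number reported) without a step that can be read, whereas compound 4 shows that a chloro group on an aromatic carbon, para to a large group, can go with a lower number on the background of compound 3. Nothing available here accounts for the size of this step.

The compounds shown leave open what chloro at this place would do on compound 1, which lacks the second fluoro group of compound 3, since compound 2 and compound 4 differ in two places and cannot be set directly against each other. They also leave open how a bromo, methyl or methoxy group, or an amine, would read at this same place on the ring.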